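The compounds below may be only part of what the source reports. "The series", "measured", "known", "first", "only" and "open" are said of these compounds alone.

Measured compounds:
- compound 1, `CC(C)(C)c1cc(NC(=O)[C@@H]2CCCCN2Cc2ccc(Cl)cc2)no1`, gives 0.15 h
- compound 2, `CC(C)(C)c1cc(NC(=O)[C@@H]2CCCCN2C2CC2)no1`, gives 0.183 h
- compound 3, `CC(C)(C)c1cc(NC(=O)[C@@H]2CCCCN2C(=O)C2CCCCC2)no1`, gives 0.483 h

All three numbers come from an ADME assay (liver) for metabolic stability, with Liver microsome (Homo sapiens) as the target, read by LC-MS, using microsomes and NADPH, tested at 1 uM; on this read-out lower numbers stand for a shorter-lived compound and higher numbers for a longer-lived compound. Compound 1 has the lowest number of the three. Its gap to compound 2, a 1.2-fold higher number from compound 1 to compound 2 (0.09 log units; within the scatter), is within the scatter, so those two cannot be told apart. Its gap to compound 3, a 3.2-fold higher number from compound 1 to compound 3 (0.51 log units; beyond the scatter), is modest but beyond the scatter.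

Compound 4, `CC(C)(C)c1cc(NC(=O)[C@@H]2CCCCN2C(=O)N2CCCCC2)no1`, differs from compound 1 in one place: (piperidin-1-yl)carbonyl in place of 4-chlorobenzyl on an amine nitrogen in a ring. The measured step that bears most on this change is a 3.2-fold higher number from compound 1 to compound 3 (0.51 log units; beyond the scatter), where the 4-chlorobenzyl was also replaced by a group carrying a carbonyl. The step of a 2.6-fold higher number from compound 2 to compound 3 (0.42 log units; beyond the scatter) points the same way. On that basis compound 4 is expected to show a modest rise over compound 1, a 3.0-fold higher number from compound 1 to compound 4 (0.48 log units; beyond the scatter), in this assay. The estimate for compound 4 is therefore 0.45 h, with a range from 0.2 h to 1 h.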

Compound 4, half-life: 0.233 h
Beside the measured number, compound 4's estimate is 1.9-fold (0.29 log units) above it; measured number inside the range.
By their numbers in this assay, from the lowest: compounds 1, 2 and 4 (each within the scatter of the next); then compound 3.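

In this assay, for the compounds shown here, a carbonyl on the amine nitrogen does not by itself set the number apart: the steps to compound 4 (a 1.6-fold higher number from compound 1 to compound 4 (0.19 log units; within the scatter); a 1.3-fold higher number from compound 2 to compound 4 (0.10 log units; within the scatter)) both stay within the scatter, unlike the earlier steps to compound 3. What sits on the carbonyl also counts, as piperidin-1-yl in place of cyclohexyl on a carbonyl carbon gives a modest step beyond the scatter (a 2.1-fold lower number from compound 3 to compound 4 (0.32 log units; beyond the scatter)). No measurement here accounts for this difference between two otherwise matched compounds.

From the compounds shown here alone, it remains open whether other groups on the carbonyl, such as morpholine, a dimethylamine or a straight alkyl chain, would stay with compound 3 or with compound 4. Going by these compounds, it is also open whether the gap between those two compounds would hold on a different core.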